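Ring swap at one aromatic carbon of compound 2

This account rests on a few compounds, and the source may have more. Where it says the series, first, only, none or still open, it means among the compounds named here.

Compound 1 `O=C(NCCCCc1ccccc1)n1c(=O)oc2cc(C3CCOCC3)ccc21` gives 68 nM in an assay on HEK293 cells for inhibition of acid ceramidase (Homo sapiens), read by fluorescence, with stated times of 10 min and 3 h; a higher number here means a weaker inhibitor, a lower number a stronger inhibitor.
Compound 2 `CC(C)N1CCN(c2ccc3c(c2)oc(=O)n3C(=O)NCCCCc2ccccc2)CC1` gives 211 nM in this assay.

For the measured compounds named here, of the two compounds measured, compound 2 has the higher number, meaning it is the weaker inhibitor; the only step connecting them, a 3.1-fold higher number from compound 1 to compound 2 (0.49 log units; beyond the scatter), is a modest one. Compound 3 `CN1CCC(c2ccc3c(c2)oc(=O)n3C(=O)NCCCCc2ccccc2)CC1` has not yet been measured. It differs from compound 2 in one place: 1-methylpiperidin-4-yl in place of 4-isopropylpiperazin-1-yl on an aromatic carbon. The incoming group shares with the ring of compound 1 the feature of being joined to the aromatic carbon through a ring carbon, whereas the departing group was joined through a ring nitrogen. Going by the values given here, the only step that bears on this change is a 3.1-fold higher number from compound 1 to compound 2 (0.49 log units; beyond the scatter), which shows that replacing a ring joined by carbon with one joined by nitrogen cost some potency; the present change partly reverses that. Among the compounds with values here, the number for compound 3 is therefore expected to move down from compound 2, by a step of roughly a 1.9-fold lower number from compound 2 to compound 3 (0.28 log units; within the scatter), though with only one measured step to lean on the expectation is loose. For compound 3 the estimated value is 110 nM, in a range from 40 nM to 300 nM.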

Compound 3, half-maximal inhibitory concentration: 129 nM
Beside the measured number, compound 3's estimate is 1.2-fold (0.07 log units) below it; low and high end bracket the measured number.
By their numbers in this assay, from the lowest: compounds 1, 3 and 2 (each within the scatter of the next, the first and the last beyond it).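

The swap from 4-isopropylpiperazin-1-yl to 1-methylpiperidin-4-yl gives a 1.6-fold lower number from compound 2 to compound 3 (0.21 log units; within the scatter), so this change cannot be told apart from no change in this assay. The step to the oxan-4-yl compound, a 1.9-fold higher number from compound 1 to compound 3 (0.28 log units; within the scatter), also stays within the scatter, so 1-methylpiperidin-4-yl cannot be separated from either of the other two groups, even though those two are separated from each other by a step beyond the scatter. This aromatic carbon therefore carries three different six-membered rings with inhibition retained, and no information is available to explain the small differences among them.

The swap changes two things at once: the ring is joined through a carbon instead of a nitrogen, and a methyl replaces the isopropyl, so the compounds shown cannot say which of these matters more, and a 4-methylpiperazin-1-yl group at this place would bear on that question. Also open, from the compounds shown here alone, is how an open-chain amine or a carboxylic acid on this aromatic carbon would compare with these rings.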